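The Same Change Made Twice: Inhibition in the Rat

The source may report more compounds than this note shows. Statements on the series, on what has been measured and on what is new or still open speak of the compounds shown alone.

Measured compounds:
compound 1, `C/N=C(/NC#N)NCCCCCCn1nc(-c2ccccc2)ccc1=O`, 31.7%
compound 2, `C/N=C(/NC#N)NCCCCCn1nc(-c2ccccc2)ccc1=O`, 47.6%
compound 3, `C/N=C(/NC#N)NCCCCn1nc(-c2ccccc2)c(C)cc1=O`, 46.4%

All three were tested in a functional assay on the whole organism with Rattus norvegicus as the target, at a dose of 100 mg/kg; a higher number here means more inhibition at the dose given (going by the name of the read-out), a lower number less inhibition. Compound 1 gives 31.7%, compound 2 gives 47.6% and compound 3 gives 46.4%. Between compound 1 and compound 2 the structures differ by a group of 7 heavy atoms (3 carbon, 4 nitrogen; no ring) in place of a group of 8 heavy atoms (4 carbon, 4 nitrogen; no ring), on a saturated chain carbon, five bonds along the chain from an aromatic nitrogen, and this brings a number 15.9 percentage points higher from compound 1 to compound 2 (beyond the scatter). Compound 3 has a different core from compound 1; the difference between the two cores is not broken down here. Compound 3 and compound 2 lie within the scatter of each other, so nothing can be said about their order, while compound 3 and compound 1 differ by more than the scatter.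

Compound 4, `C/N=C(/NC#N)NCCCn1nc(-c2ccccc2)c(C)cc1=O`, has not yet been measured. It differs from compound 3 by a group of 7 heavy atoms (3 carbon, 4 nitrogen; no ring) in place of a group of 8 heavy atoms (4 carbon, 4 nitrogen; no ring), on a saturated chain carbon, three bonds along the chain from an aromatic nitrogen. This is the same kind of change as that from compound 1 to compound 2, though the place is not the same: there it was five bonds along the chain from an aromatic nitrogen, here it is three bonds along the chain. Going by the values given here, only one earlier example of this kind of change exists, so the expectation is uncertain. Since compound 1 to compound 2 gave a number 15.9 percentage points higher from compound 1 to compound 2 (beyond the scatter), a step of similar direction is expected for compound 4, but smaller, because compound 3 already stands at 46.4% and the place differs. The expected step from compound 3 to compound 4 is a number 6.6 percentage points higher from compound 3 to compound 4 (within the scatter). In this assay compound 4 is expected to give about 53%, estimated to lie between 38% and 68%.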

Compound 4, a percentage reported as inhibition, in the whole organism at one dose (the size of the read-out at that dose, not a potency): 17.2%
Beside the measured number, compound 4's estimate is 35.8 percentage points above it; the measured number lies below the stated range.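

On the core of compound 3, putting the group of 7 heavy atoms in place of the group of 8 heavy atoms, three bonds along the chain from an aromatic nitrogen, gives a number 29.2 percentage points lower from compound 3 to compound 4 (beyond the scatter) in this assay, so the earlier gain did not carry over to this core. Set side by side, the two steps point in opposite directions and clearly differ: the same change on two cores in this assay, a number 15.9 percentage points higher (beyond the scatter) from compound 1 to compound 2 and a number 29.2 percentage points lower (beyond the scatter) from compound 3 to compound 4, 45.1 percentage points apart, beyond the scatter of two such steps. This shows that, within this series, the result of this change cannot simply be transferred from one compound pair to another, but it does not show why, since the two pairs differ both in their core and in the place along the chain where the change falls, and a single pair on each core cannot separate these two differences.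

The compounds shown leave open whether the direction of the step follows the core or the place along the chain, which a pair making the change at the same place on both cores could settle. They also leave open how the whole organism would respond to an amine or a carboxylic acid in place of the group of 7 heavy atoms.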